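The source may report more compounds than this note shows. Statements on the series, on what has been measured and on what is new or still open speak of the compounds shown alone.

Compounds measured in an ADME assay on Vero cells (Chlorocebus sabaeus) for cytotoxicity, read by MTT assay, with a stated time of 48 h; a lower number here means a stronger inhibitor, a higher number a weaker inhibitor:
Compound 1 `O=C(OC1CCC(CN2CCN(c3cc(=O)c4cc(C(F)(F)F)cc([N+](=O)[O-])c4s3)CC2)CC1)c1ccccc1`: > 64 ug/mL
Compound 2 `Cc1cccc(C(=O)OC2CCC(CN3CCN(c4cc(=O)c5cc(C(F)(F)F)cc([N+](=O)[O-])c5s4)CC3)CC2)c1`: > 64 ug/mL
Compound 3 `CC(C)C(=O)OC1CCC(CN2CCN(c3cc(=O)c4cc(C(F)(F)F)cc([N+](=O)[O-])c4s3)CC2)CC1`: > 64 ug/mL

Compound 3 stands at > 64 ug/mL, which is a limit of the assay and not a number. The whole series offers only (the limit of > 64 ug/mL in this assay, at which 3 of the 3 values shown sit). Compound 4 `CCCC(=O)OC1CCC(CN2CCN(c3cc(=O)c4cc(C(F)(F)F)cc([N+](=O)[O-])c4s3)CC2)CC1` departs from compound 3 at a single place, with propyl in place of isopropyl on a carbonyl carbon. For the measured compounds named here, the steps that bear on this change are a step that the two limits leave unreadable from compound 1 to compound 3 and a step that the two limits leave unreadable from compound 2 to compound 3, both at the same group, while a step that the two limits leave unreadable from compound 1 to compound 2 lies further out on the aromatic ring of compound 2. None of them has a readable size, so they give no direction for this assay. Going by the values given here, they show only that these three compounds share the same limit. The expected change is a number no higher from compound 3 to compound 4 (the limit leaves the size open), with no shift beyond the scatter anticipated, and the assay will most likely report a limit again. For compound 4 the estimated value is 64 ug/mL, with an expected range of 35 ug/mL to 128 ug/mL.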

Compound 4, half-maximal inhibitory concentration: > 64 ug/mL
Compound 4: no number, only a limit; the forecaster's own chance of this, stated with the estimate: 85%; the middle value lies on the limit itself.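

In this assay compound 4 gives > 64 ug/mL, which is a limit of the assay and not a number. The steps joining compound 4 to compound 1, compound 2 and compound 3 therefore cannot be read: the limit of > 64 ug/mL in this assay, at which 4 of the 4 values shown sit.

The compounds shown leave open how far any of the four lies from that limit, and whether any group on the carbonyl carbon changes the reading.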